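The source may hold more compounds than are shown below. What is called first, only, known or untested is meant among the compounds shown, and "the series" means these compounds.

Measured compounds:
- compound 1, `CCOC(=O)C1=C(C)N(c2ccccc2)C=CC1c1ccccc1`, which in a functional assay, tested at 100 ug/mL (a lower number here means a stronger effect, a higher number a weaker effect of the compound at the concentration tested), gives -21.5%
- compound 2, `CCOC(=O)C1=C(C)N(c2ccc(C)cc2)C=CC1c1ccccc1`, which in this assay gives -22.9%
- compound 3, `CCOC(=O)C1=C(C)N(c2ccc(F)cc2)C=CC1c1ccccc1`, which in this assay gives -25.7%

All three share one core and differ only in the group carried on one phenyl ring. On these numbers compound 3 cannot be told apart from its two neighbours: the step of a number 4.2 percentage points lower from compound 1 to compound 3 (within the scatter) and the step of a number 2.8 percentage points lower from compound 2 to compound 3 (within the scatter) both lie within the usual scatter of repeated measurements, as does a number 1.4 percentage points lower from compound 1 to compound 2 (within the scatter). Nothing among the three changes stands out as a real effect.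

Compound 4, `CCOC(=O)C1=C(C)N(c2ccc(Cl)cc2)C=CC1c1ccccc1`, carries the change (chloro in place of fluoro on an aromatic carbon). The measured steps that come closest to this are the two that put fluoro onto the same ring, from compound 1 and from compound 2, and both were within the scatter. Every swap of a small group at this place has so far left this assay essentially unchanged, so the expected step of a number 0.3 percentage points lower from compound 3 to compound 4 (within the scatter) is one of no size beyond the scatter, in no particular direction. The number expected for compound 4 is therefore -26%, with a range from -40% to -12%.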

Compound 4, a percentage reported as activity, at one concentration (the size of the read-out at that concentration, not a potency): -19.1%
Compound 4: the middle estimate sits 6.9 percentage points below what was measured; the measured number falls inside the stated range.
By their numbers in this assay, from the lowest: compounds 3, 2, 1 and 4 (each within the scatter of the next).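

With chloro, four groups have now been compared at this place on the ring, para to a large group, and in this assay all three new comparisons remain small (a number 6.6 percentage points higher from compound 3 to compound 4 (within the scatter); a number 3.8 percentage points higher from compound 2 to compound 4 (within the scatter); a number 2.4 percentage points higher from compound 1 to compound 4 (within the scatter)). The earlier steps shown here all ended on lower numbers and these end on higher ones, but that reversal carries no meaning: every step lies within the scatter, so hydrogen, methyl, fluoro and chloro cannot be told apart at this place. No separate measurement bears on what lies behind this flat picture.

The compounds shown leave open whether an amine, a carboxylic acid or a longer chain such as butyl at this same place would shift the read-out beyond the scatter, as all four groups compared so far are small and none of them carries a charge. They also leave open what a change elsewhere on the shared core, such as replacing the ethyl ester, would do, and whether the effect of any of the compounds would be stronger or weaker at another concentration, as the read-out comes from a single concentration.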